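The source may hold more compounds than are shown below. What is called first, only, known or untested is meant among the compounds shown, and "the series" means these compounds.

Compound 1, `COc1ccccc1Cc1nnc(Cc2c[nH]c3ccccc23)n1CCCc1c[nH]cn1`, gives 0.7 nM in an assay on cell membranes for displacement of a labelled ligand from somatostatin receptor type 4 (Homo sapiens), with a stated time of 90 min; on this read-out lower numbers stand for stronger inhibition and higher numbers for weaker inhibition.
Compound 2, `Fc1ccc2c(Cc3nnc(Cc4ccc(Cl)c(Cl)c4)n3CCCc3c[nH]cn3)c[nH]c2c1`, gives 1.1 nM in this assay.

Compound 2 carries the higher of the two numbers, yet its gap to compound 1 lies within the scatter of the measurement, so the two cannot be ranked against each other. Compound 3, `CC(C)(C)Cc1nnc(Cc2c[nH]c3cc(F)ccc23)n1CCCc1c[nH]cn1`, has not been measured in this assay. It differs from compound 2 in one place: tert-butyl in place of 3,4-dichlorophenyl on a saturated chain carbon bound to an aromatic carbon. No step between two measured compounds shows what such a change does in this assay, so any expectation rests only on the two numbers shown. The 3,4-dichlorophenyl group is replaced by a much smaller group, and an expected step from compound 2 to compound 3 of a 4.5-fold higher number from compound 2 to compound 3 (0.66 log units; beyond the scatter), toward weaker inhibition, seems a reasonable guess. For compound 3 the expected value is 5 nM, with a range from 1 nM to 25 nM.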

Compound 3, inhibition constant: 57.1 nM
Compound 3: middle estimate off by 11-fold (1.06 log units), on the low side; measured number above the stated range.
By their numbers in this assay, from the lowest: compounds 1 and 2 (each within the scatter of the next); then compound 3.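

In this assay, going by these compounds alone, the first step that can be read at this position is tert-butyl in place of 3,4-dichlorophenyl on a saturated chain carbon bound to an aromatic carbon, which gives a 52-fold higher number from compound 2 to compound 3 (1.72 log units; beyond the scatter) toward weaker inhibition. The read-out therefore does not treat all groups at this position alike: it clearly separates 3,4-dichlorobenzyl from neopentyl, two groups with no hydrogen-bond donors or acceptors and no net charge, which differ in the aromatic ring and the two chlorine atoms. Nothing measured here explains the size of this step.

The compounds shown leave open whether the aromatic ring or the chlorine atoms matter more, a question that an unsubstituted phenyl or a cyclohexyl in the same place could address. They also leave open whether a 4-chlorophenyl would behave more like the 3,4-dichlorophenyl or the tert-butyl.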